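Shortening the Linker Chain: Compound 1 to Compound 4

The source may report more compounds than this note shows. Statements on the series, on what has been measured and on what is new or still open speak of the compounds shown alone.

compound 1 `O=C1NCCN1CCCCN1CCC(c2cn(-c3ccc(F)cc3)c3ccc(Cl)cc23)CC1` — > 2.2 umol/kg
compound 2 `Fc1ccc(-n2cc(C3=CCNCC3)c3cc(Cl)ccc32)cc1` — 1.5 umol/kg
compound 3 `O=C1NCCN1CCN1CC=C(c2cn(-c3ccc(F)cc3)c3ccc(C(F)(F)F)cc23)CC1` — > 0.66 umol/kg

Of the compounds shown here, three have been tested in a functional assay on the whole organism for inhibition, with Rattus norvegicus as the target; on this read-out higher numbers stand for an effect only at larger amounts of compound and lower numbers for an effect already at smaller amounts. For compound 1 the value > 2.2 umol/kg is a limit of the assay, not a number. Compound 3 likewise gives only a limit, > 0.66 umol/kg. Compound 2 gives 1.5 umol/kg. Compound 1 therefore stands at one of the two limits among the three values, namely (the limit of > 2.2 umol/kg in this assay, at which 1 of the 3 values shown sits). Compound 4 `O=C1NCCN1CCCN1CCC(c2cn(-c3ccc(F)cc3)c3ccc(Cl)cc23)CC1` differs from compound 1 by 2-oxoimidazolidin-1-yl in place of (2-oxoimidazolidin-1-yl)methyl on a saturated chain carbon, three bonds along the chain from an amine nitrogen in a ring. Among the compounds with values here, no step between measured compounds is available to size this change, so a step no larger than the usual scatter, in either direction, is expected. For compound 4 the estimate is 3 umol/kg (range 1 umol/kg to 10 umol/kg), which expects a step that the limit leaves unreadable from compound 1 to compound 4, and a limit rather than a number remains a likely outcome.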

Compound 4, dose for half-maximal effect: 1.8 umol/kg
Beside the measured number, compound 4's estimate is 1.7-fold (0.22 log units) above it; the measured number falls inside the stated range.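

Compound 1 stands at a limit rather than a number: the limit of > 2.2 umol/kg in this assay, at which 1 of the 4 values shown sits. Within the data shown here, with the 3-(2-oxoimidazolidin-1-yl)propyl chain, compound 4 gives a true value in this assay and so provides the first number for this chain on the saturated core. From the compounds shown here alone, the step reads as an at least 1.2-fold lower number from compound 1 to compound 4 (0.08 log units; that floor lies within the scatter) and shows only that the chain can lose this carbon with the effect still measurable, while its true size stays unknown.

Still open, going by these compounds, is how a longer chain would behave at this position. On these data alone, it is also open whether an amine or a carboxylic acid could replace the 2-oxoimidazolidin-1-yl group.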